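Styryl replacement on the sulfonamide series

The source may report more compounds than this note shows. Statements on the series, on what has been measured and on what is new or still open speak of the compounds shown alone.

Within the data shown here, in an assay on mitochondria (strain BALB/c) for inhibition of glycerol-3-phosphate acyltransferase 1, mitochondrial (Mus musculus), read by scintillation counting, with a stated time of 10 min (a lower number here means a stronger inhibitor, a higher number a weaker inhibitor), compound 2 `CCCCCCCCS(=O)(=O)Nc1ccc(-c2ccccc2F)cc1C(=O)O` gives 34600 nM, the highest of the two numbers so far; compound 1 `CCCCCCCCS(=O)(=O)Nc1ccc(-c2ccccc2-c2ccccc2)cc1C(=O)O` gives 10100 nM. Compound 3 `CCCCCCCCS(=O)(=O)Nc1ccc(/C=C/c2ccc(OC)cc2)cc1C(=O)O` carries 2-(4-methoxyphenyl)ethenyl in place of 2-fluorophenyl on an aromatic carbon. Among the measured compounds shown here, one measured step bears on this change, at the same aromatic carbon: a 3.4-fold higher number from compound 1 to compound 2 (0.53 log units; beyond the scatter), where the larger group went with the lower number. Compound 3 enlarges the group again, so a lower number than for compound 2 is expected, about the size of a 2.9-fold lower number from compound 2 to compound 3 (0.46 log units; beyond the scatter). The estimate for compound 3 in this assay is 12000 nM, with a range from 3500 nM to 40000 nM.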

Compound 3, half-maximal inhibitory concentration: 37100 nM
Compound 3: the middle estimate sits 3.1-fold (0.49 log units) below what was measured, within the range that was stated.
By their numbers in this assay, from the lowest: compound 1; then compounds 2 and 3 (each within the scatter of the next).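

At this aromatic carbon, 2-(4-methoxyphenyl)ethenyl in place of 2-fluorophenyl gives a 1.1-fold higher number from compound 2 to compound 3 (0.03 log units; within the scatter) in this assay, so the two groups cannot be told apart here. Compound 3 goes against any reading that a larger group at this carbon brings a lower number, and among the three only compound 1 gives 10100 nM as a distinctly lower value. No measurement at hand explains this result.

The change replaces the whole group, leaving the separate parts of the double bond and the methoxy unresolved. From the compounds shown here alone, how an amine or a carboxylic acid on the terminal ring would read also stays open.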